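Swapping an ester for a chloro-substituted acid on the aryl ether

The source may hold more compounds than are shown below. What is called first, only, known or untested is meant among the compounds shown, and "the series" means these compounds.

Measured compounds:
compound 2, `Cc1c(OCCCCOc2ccccc2C(=O)O)ccc(C(=O)CC2CCCC2)c1C`, 2580 nM
compound 3, `CCCC(=O)c1ccc(OCCCCOc2ccc(F)c(C(=O)O)c2)c(C)c1O`, 74 nM

Compound 1, `COC(=O)c1ccc(OCCCCOc2ccc(C(=O)CC3CCCC3)c(O)c2C)cc1`, is recorded in an assay on HEK293 cells for positive allosteric modulation of metabotropic glutamate receptor 2 (Rattus norvegicus), read by thallium flux, with a stated time of 2.5 min (on this read-out lower numbers stand for an effect already at smaller amounts and higher numbers for an effect only at larger amounts of compound), as "not determined" (no result reported); nothing is reported for it, so it stands nowhere on this scale. Compound 4, `Cc1c(OCCCCOc2ccc(C(=O)O)cc2Cl)ccc(C(=O)CC2CCCC2)c1O`, differs from it in one place: 4-carboxy-2-chlorophenyl in place of 4-(methoxycarbonyl)phenyl on an oxygen on a saturated carbon. Among the compounds with values here, with no number for compound 1, no step can be sized or given a direction. The expectation for compound 4 rests instead on compound 2 and compound 3, which both carry a carboxy group on the aryl ether and lie far apart; compound 4 resembles compound 3 most closely. Compound 4 is therefore expected to give about 200 nM in this assay, within a range from 40 nM to 1500 nM.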

Compound 4, half-maximal effective concentration: 237 nM
Compound 4: middle estimate off by 1.2-fold (0.07 log units), on the low side; the measured number falls inside the stated range.
By their numbers in this assay, from the lowest: compound 3; then compound 4; then compound 2.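

No step can be read between compound 1 and compound 4, since compound 1 has no number on this scale. The compounds shown leave open what putting 4-carboxy-2-chlorophenyl in place of 4-(methoxycarbonyl)phenyl does by itself. Nothing further here bears on this result.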